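The source may report more compounds than this note shows. Statements on the series, on what has been measured and on what is new or still open speak of the compounds shown alone.

Working notes on the series. In a functional assay on A549 cells (Homo sapiens) for cytotoxicity, read by MTT assay, with a stated time of 72 h (a higher number here means a weaker inhibitor, a lower number a stronger inhibitor), compound 1 (`COc1cccc(/C=C2\CCC/C(=C\c3cccc(Cl)c3Cl)C2=O)c1OC`) gives > 20000 nM, a limit of the assay and not a number. Compound 2 (`COc1cccc(/C=C2\CCC/C(=C\c3ccc(Cl)c(Cl)c3)C2=O)c1OC`) gives > 20000 nM, likewise a limit and not a number. Compound 2 therefore has no readable position, and the whole record so far is the limit of > 20000 nM in this assay, at which 2 of the 2 values shown sit.

Next is compound 3 (`COc1cccc(/C=C2\CCC/C(=C\c3cc(Cl)cc(Cl)c3)C2=O)c1OC`), with 3,5-dichlorophenyl in place of 3,4-dichlorophenyl on a double-bonded chain carbon bound to a double-bonded ring carbon. The two have the same atoms, joined differently.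

Within the data shown here, the only measured step of this kind is a step that the two limits leave unreadable from compound 1 to compound 2, where 3,4-dichlorophenyl replaces 2,3-dichlorophenyl at the same place. That step offers no size to carry over, so no step beyond the scatter is expected in this assay, and no direction is favoured. The estimated step is a number no higher from compound 2 to compound 3 (the limit leaves the size open), and a further limit is the most likely report. For compound 3 the expected value is 20000 nM, with an estimated range of 9000 nM to 30000 nM.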

Compound 3, half-maximal inhibitory concentration: 12500 nM
Estimate against measurement, compound 3: 1.6-fold (0.20 log units) above, and the stated range covers the measured number.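

Compound 3 is the only compound shown that gives a number and not a limit in this assay: compound 3 gives 12500 nM. The change of the dichlorophenyl pattern at this place, with the same atoms joined differently, can now be given a floor, as an at least 1.6-fold lower number from compound 2 to compound 3 (0.20 log units; that floor lies within the scatter) and an at least 1.6-fold lower number from compound 1 to compound 3 (0.20 log units; that floor lies within the scatter), while the step between the 2,3-dichlorophenyl and 3,4-dichlorophenyl compounds still cannot be read. The position thus gives one readable result among three dichlorophenyl patterns, and the rest of the record stays at the limit: the limit of > 20000 nM in this assay, at which 2 of the 3 values shown sit.

As far as these compounds go, the true size of the steps to compound 3 remains open, and with it whether the 3,5-dichlorophenyl pattern truly separates from the other two beyond the scatter. Also open, from the compounds shown here alone, is how this assay would read with other groups on the double-bonded chain carbon bound to a double-bonded ring carbon, such as a 3,5-dimethoxyphenyl, a 3,5-difluorophenyl or a phenyl carrying an amine, and what the rest of the shared core contributes.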